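Replacing 4-ethylpiperazin-1-yl in compound 2

The source may hold more compounds than are shown below. What is called first, only, known or untested is meant among the compounds shown, and "the series" means these compounds.

Compound 1 `CN1CCN(c2cc(C(F)(F)F)nc(SCc3ccc(C(F)(F)F)cc3)n2)CC1` gives 34700 nM in a functional assay on PC-3 cells (Homo sapiens) for inhibition, read by MTT assay, with a stated time of 72 h; a lower number here means a stronger inhibitor, a higher number a weaker inhibitor
Compound 2 `CCN1CCN(c2cc(C(F)(F)F)nc(SCc3ccc(C(F)(F)F)cc3)n2)CC1` gives 27200 nM in this assay

Among the compounds with values here, compound 2 stands level with compound 1, as the only measured step, a 1.3-fold lower number from compound 1 to compound 2 (0.11 log units; within the scatter), shows. Compound 3 `FC(F)(F)c1ccc(CSc2nc(Sc3ncccn3)cc(C(F)(F)F)n2)cc1` differs from compound 2 as follows: (pyrimidin-2-yl)sulfanyl in place of 4-ethylpiperazin-1-yl on an aromatic carbon. The measured step only adds methyl in place of hydrogen within the group that now leaves, so it bears weakly on this exchange. Within the data shown here, no measured compound carries (pyrimidin-2-yl)sulfanyl. Going by these compounds, the estimated change in this assay is a 1.1-fold lower number from compound 2 to compound 3 (0.04 log units; within the scatter), which is no step beyond the scatter, and its direction remains open. For compound 3 the expected value is 25000 nM, with an estimated range from 8000 nM to 70000 nM.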

Compound 3, half-maximal inhibitory concentration: > 50000 nM
Compound 3: only a limit was reported (the forecaster's own chance of this, stated with the estimate: 20%); at least 2.0-fold (0.30 log units) between middle value and limit.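

In this assay compound 3 gives > 50000 nM, which is a limit and not a number. The exchange on this aromatic carbon gives an at least 1.8-fold higher number from compound 2 to compound 3 (0.26 log units; that floor lies within the scatter) and an at least 1.4-fold higher number from compound 1 to compound 3 (0.15 log units; that floor lies within the scatter), so leaving the piperazine groups brings no gain, yet neither floor shows a loss beyond the scatter. How far compound 3 lies from the others cannot be read because of the limit: the limit of > 50000 nM in this assay, at which 1 of the 3 values shown sits.

The sulfur link and the aromatic ring enter together, so the compounds shown do not separate them. Also open, going by these compounds, is how a morpholine or an open-chain amine would read on this carbon.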